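Moving the Bromine on Two Related Cores

This account rests on a few compounds, and the source may have more. Where it says the series, first, only, none or still open, it means among the compounds named here.

Compound 1 `Cn1c(-c2cccc(Br)c2)cs/c1=N\C(=O)c1ccccc1` and compound 2 `Cn1c(-c2ccc(Br)cc2)cs/c1=N\C(=O)c1ccccc1` share one core and differ only in 4-bromophenyl in place of 3-bromophenyl on an aromatic carbon. In a functional assay on MDA-MB-231 cells (Homo sapiens), read by microscopy and transwell migration, with a stated time of 24 h (on this read-out lower numbers stand for stronger inhibition and higher numbers for weaker inhibition), compound 1 gives 302 nM, and compound 2 gives 125 nM, so that the change brings a 2.4-fold lower number from compound 1 to compound 2 (0.38 log units; beyond the scatter). Compound 3 `CN(C(=O)c1ccccc1)c1nc(-c2cccc(Br)c2)cs1` rests on a second core; the difference between the two cores is not broken down here. In this assay compound 3 gives 437 nM, the highest of the three numbers. Compound 4 `CN(C(=O)c1ccccc1)c1nc(-c2ccc(Br)cc2)cs1` differs from compound 3 by 4-bromophenyl in place of 3-bromophenyl on an aromatic carbon, the same kind of change, though its place differs: in compound 1 the carbon lies next to the ring atom that bears a methyl group, while in compound 3 it lies two ring bonds from the ring atom that bears a large group. Compound 4 is expected to show a step of a 2.4-fold lower number from compound 3 to compound 4 (0.39 log units; beyond the scatter), resting on a 2.4-fold lower number from compound 1 to compound 2 (0.38 log units; beyond the scatter). Compound 4 is therefore estimated at 180 nM, between 90 nM and 400 nM.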

Compound 4, half-maximal inhibitory concentration: 317 nM
Estimate against measurement, compound 4: 1.8-fold (0.25 log units) below, and the stated range covers the measured number.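

In this assay, putting 4-bromophenyl in place of 3-bromophenyl on the core of compound 3 gives a 1.4-fold lower number from compound 3 to compound 4 (0.14 log units; within the scatter), whereas the same change on the core of compound 1 gives a step beyond the scatter. Set side by side, the two steps cannot be told apart: the same change on two cores in this assay, a 2.4-fold lower number (0.38 log units; beyond the scatter) from compound 1 to compound 2 and a 1.4-fold lower number (0.14 log units; within the scatter) from compound 3 to compound 4, 1.8-fold (0.24 log units) apart, within the scatter of two such steps. For the compounds shown here, this shows that the two cores do not demonstrably respond differently to the change, but it does not show that the change carries over with a fixed size, as the step on the core of compound 3 cannot be told from none and only two cores are compared.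

Going by these compounds, it remains open how a chlorine or a methoxy group in place of the bromine would read on either core. On these data alone, the effect of an amine or a carboxylic acid on the benzoyl group is also open.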